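This account rests on a few compounds, and the source may have more. Where it says the series, first, only, none or still open, it means among the compounds named here.

Three compounds share one core and were tested in a functional assay on A549 cells (Homo sapiens) for cytotoxicity, read by MTT assay, with a stated time of 72 h; on this read-out lower numbers stand for stronger inhibition and higher numbers for weaker inhibition. Compound 1 `COc1c(OCCCCN2CCN(C)CC2)cc(O)c2c(=O)cc(-c3ccc(C)cc3)oc12` gives 3810 nM. Compound 2 `Cc1ccc(COc2cc(O)c3c(=O)cc(-c4ccccc4)oc3c2OCCCCN2CCN(C)CC2)cc1` gives 3200 nM. Compound 3 `CN1CCN(CCCCOc2c(OCc3ccc(C#N)cc3)cc(O)c3c(=O)cc(-c4ccccc4)oc23)CC1` gives 2140 nM, the lowest of the three numbers, though its gaps to compound 2 and to compound 1 both lie within the usual scatter, so no ordering among the three can be claimed. Among the measured compounds shown here, the only single-point step in this set is a 1.5-fold lower number from compound 2 to compound 3 (0.17 log units; within the scatter), a change that stayed within the scatter.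

Compound 4 `CN1CCN(CCCCOc2c(OCc3cccs3)cc(O)c3c(=O)cc(-c4ccccc4)oc23)CC1` differs from compound 3 in one place: thiophen-2-yl in place of 4-cyanophenyl on a saturated chain carbon bound to an oxygen on an aromatic ring. For the measured compounds named here, this is a swap of the aromatic group hanging from the same chain carbon, and the one measured step at that position, the one from compound 2 to compound 3, moved the number by less than the scatter. Going by the values given here, on that basis, and with no larger step in this set to point elsewhere, the change to compound 4 is expected to bring no shift beyond the scatter in this assay, that is a 1.2-fold higher number from compound 3 to compound 4 (0.07 log units; within the scatter). Compound 4 is therefore estimated at 2500 nM, with a likely range from 1200 nM to 5200 nM.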

Compound 4, half-maximal inhibitory concentration: 2100 nM
Compound 4: middle estimate off by 1.2-fold (0.08 log units), on the high side; low and high end bracket the measured number.
By their numbers in this assay, from the lowest: compounds 4, 3, 2 and 1 (each within the scatter of the next).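

In this assay, the swap at this position now goes beyond a change on the phenyl ring: the whole aromatic group on the saturated chain carbon bound to an oxygen on an aromatic ring is replaced. Thiophen-2-yl in place of 4-cyanophenyl gives a 1.0-fold lower number from compound 3 to compound 4 (0.01 log units; within the scatter), and thiophen-2-yl in place of 4-methylphenyl gives a 1.5-fold lower number from compound 2 to compound 4 (0.18 log units; within the scatter). So a five-membered aromatic ring with a sulfur, at 5 heavy atoms against 8 for 4-cyanophenyl and with no nitrile, leaves the number within the scatter of both six-membered partners, though nothing measured here accounts for this result.

All three aromatic groups at this position read alike, so the compounds shown do not reveal what, if anything, would move the number here. A cyclohexyl ring, an amine or a carboxylic acid in place of the aromatic group, or a longer chain between the oxygen and that group, could either give a step beyond the scatter or leave the number where it is.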